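The compounds below may be only part of what the source reports. "The series", "measured", "known", "first", "only" and "open" are said of these compounds alone.

In a functional assay on A-375 cells (Homo sapiens) for inhibition, read by CCK-8 assay, with a stated time of 72 h, tested at 8 uM (on this read-out higher numbers stand for more inhibition of growth at the one concentration tested and lower numbers for less inhibition of growth), compound 2 (`Nc1ccccc1NC(=O)c1ccc(CSc2ccc(Br)cc2)cc1`) gives 6.17%. This places it within the scatter of compound 1 (`Nc1ccccc1NC(=O)/C=C/c1ccc(CSc2cccc(F)c2)cc1`), which gives 9.08%. Compound 3 (`Nc1ccccc1NC(=O)/C=C/c1ccc(CSCCc2ccccc2)cc1`) gives 37.4%, a value beyond the scatter from compound 2.

The step followed here leads from compound 2 to compound 4 (`Nc1ccccc1NC(=O)c1ccc(CSc2ccc(Cl)cc2)cc1`). The change is chloro in place of bromo on an aromatic carbon, para to a large group, with the rest of the structure unchanged.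

Within the data shown here, only one measured step is available, a number 28.3 percentage points higher from compound 1 to compound 3 (beyond the scatter). It is modest but beyond the scatter, and it comes from phenethyl in place of 3-fluorophenyl on a sulfur. Among the measured compounds shown here, that is an exchange of the whole group on sulfur, so it gives no direct measure for a swap of bromo for chloro, and no measured pair makes that swap. A step of that size is therefore not expected here, and no shift beyond the scatter is anticipated in either direction. The expectation starts from compound 2 at 6.17%. The estimated change is a number 1.8 percentage points higher from compound 2 to compound 4 (within the scatter), which is expected to remain within the scatter. Compound 4 is expected to give about 8%, with an estimated range of 0% to 20%.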

Compound 4, percent growth inhibition at one concentration: 48.6%
Estimate against measurement, compound 4: 40.6 percentage points below; measured number above the stated range.
By their numbers in this assay, from the lowest: compounds 2 and 1 (each within the scatter of the next); then compound 3; then compound 4.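

In this assay, among these compounds, the exchange of 4-bromophenyl for 4-chlorophenyl on the sulfur gives the first measured step at this position, and it is large: a number 42.4 percentage points higher from compound 2 to compound 4 (beyond the scatter). Among the compounds shown here, the only earlier step, a number 28.3 percentage points higher from compound 1 to compound 3 (beyond the scatter), replaced the whole group on sulfur, whereas this pair shows that swapping a single halogen, one heavy atom for one heavy atom with no change in the counted donors, acceptors or net charge, is enough to carry the read-out beyond the scatter, and by a wider margin than that earlier exchange. Nothing at hand explains the size of this step, which therefore stands as an observation from a single pair of compounds.

As far as these compounds go, it remains open whether the same exchange would give a step of similar size in a compound with the carbon-carbon double bond of compound 1 and compound 3, as this one pair tests it only on the core of compound 2. From the compounds shown here alone, it is also open how an amine, a methoxy group or a trifluoromethyl group on the same aromatic carbon, para to a large group, would read in this assay.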